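The source may hold more compounds than are shown below. What is called first, only, known or untested is meant among the compounds shown, and "the series" means these compounds.

Measured compounds in a functional assay on the whole organism with Mus musculus as the target; a higher number here means a larger maximal response, a lower number a smaller maximal response:
Compound 1 `C=CCn1c(=S)n(C2OC(COCc3ccccc3)[C@H]3OC(C)(C)O[C@@H]23)c2nc(N)nc(O)c21` gives 0%
Compound 2 `CCOC(=O)Cn1c(=O)n(C2OC(CO)[C@@H](O)[C@H]2O)c2nc(N)nc(O)c21` gives 58%
Compound 3 `Cn1c(=O)n(C2OC(CO)[C@@H](O)[C@H]2O)c2nc(N)nc(O)c21` gives 100%

Compound 1 stands lowest of the three; compound 2 is nearest to it and compound 3 furthest, both beyond the usual scatter. Among the measured compounds shown here, the only single-place step measured is a number 42 percentage points higher from compound 2 to compound 3 (beyond the scatter), a large one, but it changes a group on a saturated chain carbon bound to an aromatic nitrogen, not the place altered here.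

Compound 4 `C=CCn1c(=S)n(C2OC(COC(C)=O)[C@H]3OC(C)(C)O[C@@H]23)c2nc(N)nc(O)c21` differs from compound 1 by acetyl in place of benzyl on an oxygen on a saturated carbon. For the measured compounds named here, no measured step touches this oxygen, so nothing in the data points to a rise or a fall, and compound 1 already sits at the floor. For compound 4 the expected step is a number 5 percentage points higher from compound 1 to compound 4 (within the scatter), no change beyond the scatter. Compound 4 is thus estimated at 5%, in the range 0% to 25%.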

Compound 4, largest response reached (reported as maximal response), in percent of the reference or control that the assay uses: 20%
For compound 4 the middle estimate is 15 percentage points below the measured one, and the stated range covers the measured number.
By their numbers in this assay, from the lowest: compound 1; then compound 4; then compound 2; then compound 3.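

In this assay, acetyl in place of benzyl on this oxygen gives a number 20 percentage points higher from compound 1 to compound 4 (beyond the scatter). The group at this place can therefore lift the maximal response off the bottom of the scale, even with the rest of compound 1 unchanged. No measurement on hand explains the rise. From the compounds shown here alone, it remains open whether the rise comes from losing the benzyl or from gaining the acetyl. A benzoyl group or a longer acyl chain such as hexanoyl on the same oxygen could help separate the two.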